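Notes on the step from compound 2 to compound 3

The source may hold more compounds than are shown below. What is called first, only, known or untested is meant among the compounds shown, and "the series" means these compounds.

In a functional assay on MDA-MB-435 cells (Homo sapiens) for inhibition, read by sulforhodamine B assay, with a stated time of 48 h (on this read-out lower numbers stand for stronger inhibition and higher numbers for weaker inhibition), compound 1 (`CN1CCCN(CCNc2nccc(-c3c(-c4cccc(O)c4)nc4sccn34)n2)S1(=O)=O`) gives 490 nM, and compound 2 (`O=S(=O)(NCCCNc1nccc(-c2c(-c3cccc(O)c3)nc3sccn23)n1)c1cccc(F)c1`) gives 2000 nM, the higher of the two numbers. For the measured compounds named here, compound 3 (`O=S(=O)(NCCNc1nccc(-c2c(-c3cccc(O)c3)nc3sccn23)n1)c1ccc(F)cc1`) has no measurement yet. The change from compound 2 is ((4-fluorophenyl)sulfonyl)amino in place of (((3-fluorophenyl)sulfonyl)amino)methyl on a saturated chain carbon, two bonds along the chain from a nitrogen on an aromatic ring: ((4-fluorophenyl)sulfonyl)amino in place of (((3-fluorophenyl)sulfonyl)amino)methyl. Going by the values given here, the only measured step is a 4.1-fold higher number from compound 1 to compound 2 (0.61 log units; beyond the scatter). Among the compounds with values here, this modest step involves a different group, so it bears on the change only indirectly, and no measured pair isolates this exchange. A small move towards lower numbers is therefore expected, with no clear step beyond the scatter. The expected step is a 1.7-fold lower number from compound 2 to compound 3 (0.22 log units; within the scatter). In this assay the estimated value for compound 3 is 1200 nM, with an expected range of 400 nM to 3500 nM.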

Compound 3, half-maximal inhibitory concentration: 939 nM
Compound 3: middle estimate off by 1.3-fold (0.11 log units), on the high side; measured number inside the range.
By their numbers in this assay, from the lowest: compounds 1 and 3 (each within the scatter of the next); then compound 2.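

In this assay the exchange of (((3-fluorophenyl)sulfonyl)amino)methyl for ((4-fluorophenyl)sulfonyl)amino gives a 2.1-fold lower number from compound 2 to compound 3 (0.33 log units; beyond the scatter) and so shows that this position responds to a change between two fluorophenyl sulfonyl groups, not only to the exchange of a ring sulfonyl group for an aromatic one. The comparison with the six-membered non-aromatic ring group gives a 1.9-fold higher number from compound 1 to compound 3 (0.28 log units; within the scatter) and so does not separate that group from ((4-fluorophenyl)sulfonyl)amino. No measurement here bears on the reason for these differences.

The step from compound 2 to compound 3 alters the methyl unit and the fluorine position in one exchange, so the share of each remains unresolved. Also open, on these data alone, is how ((3-fluorophenyl)sulfonyl)amino, an unsubstituted phenylsulfonyl group or a simple amine would read at this position.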